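Compound 4 from compound 3: chloromethyl removed from the core

This account rests on a few compounds, and the source may have more. Where it says the series, first, only, none or still open, it means among the compounds named here.

For the measured compounds named here, in a functional assay on HT-1080 cells (Homo sapiens), read by transwell migration, with a stated time of 24 h, tested at 10 uM (on this read-out higher numbers stand for a weaker effect at the one concentration tested and lower numbers for a stronger effect), compound 3 (`O=C(Oc1cccc(Cl)c1)c1cc2cc(CCl)ccc2oc1=O`) gives 67%, the highest of the three numbers so far. Compound 2 (`CCC(=O)OCc1ccc2oc(=O)c(C(=O)Oc3cccc(Br)c3)cc2c1`) gives 21.3% and compound 1 (`CC(=O)OCc1ccc2oc(=O)c(C(=O)Oc3cccc(Cl)c3)cc2c1`) gives 6.17%; both lie below compound 3 by more than the scatter.

Compound 4 (`O=C(Oc1cccc(Cl)c1)c1cc2ccccc2oc1=O`) differs from compound 3 by hydrogen in place of chloromethyl on an aromatic carbon. Going by the values given here, the only measured step at this place is a number 60.8 percentage points higher from compound 1 to compound 3 (beyond the scatter), which shows that what sits on this carbon can move the read-out far in either direction, but no measured pair shows the bare hydrogen there. Compound 1 and compound 2 carry other groups at the same place and both sit low; compound 3 alone sits high. Nothing indicates which of these the hydrogen analogue will resemble.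

For compound 4 the number in this assay is therefore estimated near the middle of the observed range, at 35%, with a wide span from 5% to 75%, which means an expected step of a number 32 percentage points lower from compound 3 to compound 4 (beyond the scatter).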

Compound 4, a percentage reported as activity, at one concentration (the size of the read-out at that concentration, not a potency): 35.7%
Beside the measured number, compound 4's estimate is 0.7 percentage points below it; the range from low to high includes it.
By their numbers in this assay, from the lowest: compound 1; then compound 2; then compound 4; then compound 3.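

In this assay there is a number 31.3 percentage points lower from compound 3 to compound 4 (beyond the scatter) and a number 29.5 percentage points higher from compound 1 to compound 4 (beyond the scatter) at the same aromatic carbon, so hydrogen now serves as a reference point for this position. Measured against hydrogen, the two groups part in opposite directions: chloromethyl goes with the weaker effect at the one concentration tested and acetoxymethyl with the stronger, a split that the earlier step between those two groups alone could not show. No available evidence bears on the reason for this split.

From the compounds shown here alone, whether an aminomethyl, a carboxylic acid or a hydroxymethyl group on this carbon would fall near chloromethyl, near acetoxymethyl or near hydrogen stays open. Also open, going by these compounds, is whether an ester with a longer chain in place of the acetoxymethyl group of compound 1 would keep the low number, with all else unchanged.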